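The compounds below may be only part of what the source reports. "The series", "measured", "known", "first", "only" and "open" are said of these compounds alone.

Compound 1 `Nc1ccc2cccc(OCC3CCCC3)c2n1`: 53 nM
Compound 2 `Nc1ccc2cccc(OCCC(F)(F)F)c2n1`: 722 nM
Compound 3 `CC(C)OCCOc1cccc2ccc(N)nc12`: not yet measured

For the measured compounds named here, in an assay on cells with melanin-concentrating hormone receptor 1 (Homo sapiens) as the target, read by radioligand binding (on this read-out higher numbers stand for weaker inhibition and lower numbers for stronger inhibition), compound 2 gives the higher of the two numbers so far; the step of a 14-fold higher number from compound 1 to compound 2 (1.13 log units; beyond the scatter) separates it from compound 1. Compound 3 differs from compound 2 by isopropoxy in place of trifluoromethyl on a saturated chain carbon, two bonds along the chain from an oxygen on an aromatic ring. Going by the values given here, only that one measured step touches the same chain on the shared core, and it was large, so changes at this chain have shifted the number considerably. Compound 1 also differs from compound 2 in that place, and the lower number of compound 1, 53 nM, suggests that leaving trifluoromethyl may lower the number again. For compound 3 the expected value is 250 nM, with a range from 60 nM to 1000 nM, an estimated step of a 2.9-fold lower number from compound 2 to compound 3 (0.46 log units; beyond the scatter).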

Compound 3, half-maximal inhibitory concentration: > 2000 nM
Compound 3 ended at the assay's limit; the forecaster's own chance of this, stated with the estimate: 5%; middle value at least 8.0-fold (0.90 log units) from the limit.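

In this assay compound 3 stands at a limit and not at a number: the limit of > 2000 nM in this assay, at which 1 of the 3 values shown sits. Isopropoxy in place of trifluoromethyl gives an at least 2.7-fold higher number from compound 2 to compound 3 (0.44 log units; beyond the scatter) and so leaving trifluoromethyl does not by itself lower the number; the direction depends on the group that enters. Set against cyclopentyl, the isopropoxymethyl group gives an at least 37-fold higher number from compound 1 to compound 3 (1.57 log units; beyond the scatter) and so compound 1 remains the lowest of the three.

From the compounds shown here alone, how far the number of compound 3 lies past its limit stays open. So does how a cyclohexyl group or a chain ending in an amine would read here.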